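Swapping the Halogenated Benzyl Arm: Chlorine to Bromine

The source may report more compounds than this note shows. Statements on the series, on what has been measured and on what is new or still open speak of the compounds shown alone.

For the measured compounds named here, compound 3 `Clc1ccc(CNc2ccc3ncnc(Nc4cccc(Br)c4)c3c2)cc1` gives 920 nM in a functional assay on HepG2 cells (Homo sapiens) for antiproliferative activity, read by MTT assay, with a stated time of 48 h (a higher number here means a weaker inhibitor, a lower number a stronger inhibitor), the lowest of the three numbers so far. Compound 2 `Fc1ccc(CNc2ccc3ncnc(Nc4cccc(Br)c4)c3c2)cc1` gives 1770 nM, and the step of a 1.9-fold lower number from compound 2 to compound 3 (0.28 log units; within the scatter) means these two cannot be told apart. Going by the values given here, compound 1 `COc1ccccc1CNc1ccc2ncnc(Nc3cccc(Br)c3)c2c1` gives 8820 nM, and the step of a 9.6-fold lower number from compound 1 to compound 3 (0.98 log units; beyond the scatter) is the only one that clearly separates compound 3 from another compound.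

Compound 4 `Brc1cccc(Nc2ncnc3ccc(NCc4ccccc4Br)cc23)c1` has not yet been measured. It differs from compound 3 by 2-bromophenyl in place of 4-chlorophenyl on a saturated chain carbon bound to a nitrogen on an aromatic ring. Two kinds of measured step bear on this. The step of a 1.9-fold lower number from compound 2 to compound 3 (0.28 log units; within the scatter) shows that exchanging one halogen for another within the same group changes little. The steps of a 9.6-fold lower number from compound 1 to compound 3 (0.98 log units; beyond the scatter) and a 5.0-fold lower number from compound 1 to compound 2 (0.70 log units; beyond the scatter) show that the 2-methoxyphenyl group gives a clearly higher number than either 4-halophenyl group, and the 2-bromophenyl group of compound 4 is named like that group rather than like the 4-chlorophenyl group. A modestly higher number than compound 3 is therefore expected in this assay, though the halogen itself argues for little change. Compound 4 is expected to give about 2500 nM, with a range from 800 nM to 8000 nM. The expected step is a 2.7-fold higher number from compound 3 to compound 4 (0.43 log units; beyond the scatter).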

Compound 4, half-maximal inhibitory concentration: 2760 nM
Estimate against measurement, compound 4: 1.1-fold (0.04 log units) below; low and high end bracket the measured number.
By their numbers in this assay, from the lowest: compounds 3, 2 and 4 (each within the scatter of the next, the first and the last beyond it); then compound 1.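

The step of a 3.2-fold lower number from compound 1 to compound 4 (0.50 log units; beyond the scatter) shows that keeping the group at the 2-position of the ring while putting bromo in place of methoxy recovers part of the gap, so the high number of compound 1 does not come from the ring position alone. Compound 4 still stands apart in the step of a 3.0-fold higher number from compound 3 to compound 4 (0.48 log units; beyond the scatter), yet the step of a 1.6-fold higher number from compound 2 to compound 4 (0.19 log units; within the scatter) leaves it indistinguishable from the 4-fluorophenyl compound, so a 2-bromophenyl arm sits within reach of the 4-halophenyl arms. No measured evidence explains these differences.

The step from compound 3 changes the halogen and its ring position together, so the two effects stay tangled. A 4-bromophenyl or 2-chlorophenyl group would separate them, and an unsubstituted phenyl would show what any substituent adds.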